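Swapping Fluoro for Cyano in a Paw-Edema Series

This account rests on a few compounds, and the source may have more. Where it says the series, first, only, none or still open, it means among the compounds named here.

Four compounds share one core. Compound 1 `CC(=O)Nc1cc(-n2c(-c3ccccc3)cc3c2CCCC3)cc(C(=O)O)c1O` carries an acetamido group, and in a functional assay on the whole organism (strain Wistar) for inhibition, with Rattus norvegicus as the target, read by paw edema, with stated times of 30 min and 3 h, at a dose of 200 mg/kg by the oral route (a lower number here means less inhibition, a higher number more inhibition at the dose given (going by the name of the read-out)), compound 1 gives 0%. Compound 2 `Cc1ccc(-c2cc3c(n2-c2ccc(O)c(C(=O)O)c2)CCCC3)cc1` gives 30% in this assay. Compound 3 `O=C(O)c1cc(-n2c(-c3ccc(F)cc3)cc3c2CCCC3)ccc1O` reports only a limit in this assay, namely >= 60%. Going by the values given here, the single measured step, a number at least 30 percentage points higher from compound 2 to compound 3 (beyond the scatter), carried the value up to that limit (the limit of >= 60% in this assay, at which 1 of the 3 values shown sits), so compound 3 stands at the top of what the numbers can show.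

Compound 4 `N#Cc1ccc(-c2cc3c(n2-c2ccc(O)c(C(=O)O)c2)CCCC3)cc1` awaits measurement. It differs from compound 3 by cyano in place of fluoro on an aromatic carbon. Among the compounds with values here, no measured step exchanges fluoro for cyano; the only step available concerns methyl and fluoro, and it was large. That step says nothing direct about a cyano group, and the reference point for compound 4 is itself a limit rather than a number. The step implied, a step that the limit leaves unreadable from compound 3 to compound 4, is therefore expected to be none beyond the scatter. Compound 4 is estimated at 65%, within a range from 40% to 85%.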

Compound 4, a percentage reported as inhibition, in the whole organism at one dose (the size of the read-out at that dose, not a potency): 0%
Estimate against measurement, compound 4: 65 percentage points above; measured number below the stated range.
By their numbers in this assay, from the lowest: compounds 1 and 4 (each within the scatter of the next); then compound 2. At a limit, above all of these: compound 3.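

In this assay, the aromatic carbon para to a large group proves highly sensitive to its substituent: the change from 4-fluorophenyl to 4-cyanophenyl gives a number at least 60 percentage points lower from compound 3 to compound 4 (beyond the scatter), and replacing methyl with cyano gives a number 30 percentage points lower from compound 2 to compound 4 (beyond the scatter). The earlier step at this position, a number at least 30 percentage points higher from compound 2 to compound 3 (beyond the scatter), went only upward, whereas these new steps show that a substituent here can also lower the value. The size of the step from fluoro to cyano remains bounded rather than exact, because compound 3 reports a limit and not a number: the limit of >= 60% in this assay, at which 1 of the 4 values shown sits.

The compounds shown do not reveal what sets the order among methyl, fluoro and cyano at this position. As far as these compounds go, how a chlorine, a methoxy group or an amine in the same place would read also remains open.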